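The compounds below may be only part of what the source reports. "The series", "measured", "known", "first", "only" and "open" are said of these compounds alone.

Measured so far in a functional assay on COLO 205 cells (Homo sapiens) for cytotoxicity, read by MTT assay, with a stated time of 72 h; on this read-out lower numbers stand for stronger inhibition and higher numbers for weaker inhibition:
compound 1 `COc1ccc(C(=O)c2cc(OC)c(OC)c(OC)c2)cc1N`: 200 nM
compound 2 `COc1cccc(/C=C/C(=O)Nc2cc(OC)c(OC)c(OC)c2)c1`: 4200 nM
compound 3 `COc1ccc(C(=O)c2cc(OC)c(OC)c(OC)c2)cc1NC(=O)/C=C/c1cc(OC)c(OC)c(OC)c1`: 5200 nM

Compound 3 holds the highest number of the three. Its nearest neighbour is compound 2, whose number differs by a gap that stays within the scatter, so no order can be read between the two. Compound 1 lies far below, and that gap is beyond the scatter.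

Compound 4 `COc1ccc(/C=C/C(=O)Nc2cc(C(=O)c3cc(OC)c(OC)c(OC)c3)ccc2OC)cc1` differs from compound 3 in one place: 4-methoxyphenyl in place of 3,4,5-trimethoxyphenyl on a double-bonded chain carbon bound to a double-bonded chain carbon. Going by the values given here, no measured pair shows this change on its own. What is known is that compound 2, whose cinnamamide does not carry the 3,4,5-trimethoxyphenyl group, lands close to compound 3: in this assay compound 2 gives 4200 nM and compound 3 gives 5200 nM. The methoxylation pattern on the cinnamamide aryl therefore appears to matter little here, though only these two compounds speak to it.

The step is expected to be a 1.0-fold lower number from compound 3 to compound 4 (0.02 log units; within the scatter), that is, none beyond the scatter. For compound 4 in this assay the estimated value is 5000 nM, with a range from 2000 nM to 15000 nM.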

Compound 4, half-maximal inhibitory concentration: 10900 nM
Compound 4: middle estimate off by 2.2-fold (0.34 log units), on the low side, within the range that was stated.
By their numbers in this assay, from the lowest: compound 1; then compounds 2 and 3 (each within the scatter of the next); then compound 4.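

In this assay, this position responds to the change: 4-methoxyphenyl in place of 3,4,5-trimethoxyphenyl on a double-bonded chain carbon bound to a double-bonded chain carbon gives a 2.1-fold higher number from compound 3 to compound 4 (0.32 log units; beyond the scatter). Going by these compounds alone, this is the only step that isolates one change, and it is modest but moves towards weaker inhibition, so the earlier impression of a position indifferent to its methoxy pattern does not hold for this pair. No available evidence accounts for the step.

On these data alone, whether 3,4-dimethoxyphenyl or unsubstituted phenyl at this place would sit with compound 3 or with compound 4 remains open. Also open, as far as these compounds go, is how an amine or a carboxylic acid on this aromatic ring would fare, and one pair cannot show whether the step carries over to other cores.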